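The source may hold more compounds than are shown below. What is called first, only, known or untested is meant among the compounds shown, and "the series" means these compounds.

Measured in a functional assay on cells (Splenocyte, Mus musculus, strain BALB/c) for inhibition, read by scintillation counting and thymidine incorporation, with a stated time of 72 h; on this read-out higher numbers stand for weaker inhibition and lower numbers for stronger inhibition:
Compound 1 `CC(/C=N/Nc1ccc([N+](=O)[O-])cc1)=N\NC(=O)c1ccc(N)cc1` gives > 12000 nM, a limit of the assay.
Compound 2 `CC(/C=N/Nc1ccc([N+](=O)[O-])cc1)=N\NC(=O)c1ccccc1F` gives > 12000 nM, likewise a limit.
Compound 3 `COc1cc(C(=O)N/N=C(C)/C=N/Nc2ccc([N+](=O)[O-])cc2)ccc1O` gives 5100 nM.

Compound 1 therefore stands at the limit of > 12000 nM in this assay, at which 2 of the 3 values shown sit, without a number of its own. Compound 4 `CC(/C=N/Nc1ccc([N+](=O)[O-])cc1)=N\NC(=O)c1ccc([N+](=O)[O-])cc1` differs from compound 1 by nitro in place of amino on an aromatic carbon. Among the compounds with values here, no measured step touches this position; the steps known swap the whole aryl on the carbonyl: a step that the two limits leave unreadable from compound 1 to compound 2, an at least 2.3-fold lower number from compound 1 to compound 3 (0.37 log units; beyond the scatter) and an at least 2.3-fold lower number from compound 2 to compound 3 (0.37 log units; beyond the scatter). Only the 4-hydroxy-3-methoxyphenyl member reaches a number, and the nitro change is not of that kind. In this assay, within the data shown here, the expectation is no step readable beyond the scatter, with compound 4 most likely again at the limit. Compound 4 is estimated at 15000 nM (range 5000 nM to 40000 nM), an expected step that the limit leaves unreadable from compound 1 to compound 4.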

Compound 4, half-maximal inhibitory concentration: 980 nM
For compound 4 the middle estimate is 15-fold (1.18 log units) above the measured one; measured number below the stated range.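

In this assay, nitro in place of amino at this position gives an at least 12-fold lower number from compound 1 to compound 4 (1.08 log units; beyond the scatter), so this single change on the aryl ring is enough to turn a limit into a number. The 4-nitrophenyl member also stands apart from the other aryl groups, with a 5.2-fold lower number from compound 3 to compound 4 (0.72 log units; beyond the scatter) and an at least 12-fold lower number from compound 2 to compound 4 (1.08 log units; beyond the scatter), so reaching a number does not depend on the 4-hydroxy-3-methoxyphenyl group. Compound 1 and compound 2 are limits, which makes two of these steps bounds only: the limit of > 12000 nM in this assay, at which 2 of the 4 values shown sit.

As far as these compounds go, whether the gain is specific to nitro remains open. A nitrile, a carboxylic acid or a methyl ester at the same place would test this.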